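Chain extension at the propargylic carbon of compound 1

The source may hold more compounds than are shown below. What is called first, only, known or untested is meant among the compounds shown, and "the series" means these compounds.

The series rests on compound 1 `CCCC(C#CC(=O)OC)O/C=C/C(=O)OC`, which in a functional assay on SW1573 cells (Homo sapiens) for antiproliferative activity, read by sulforhodamine B assay, with a stated time of 48 h (a lower number here means a stronger inhibitor of growth, a higher number a weaker inhibitor of growth), gives 320 nM, the lowest of the three numbers shown. Compound 2 `COC(=O)C#CC(O/C=C/C(=O)OC)C(C)C` carries isopropyl in place of propyl on the saturated chain carbon and gives 750 nM; the step shows a 2.3-fold higher number from compound 1 to compound 2 (0.37 log units; beyond the scatter). Compound 3 `Cc1ccc(S(=O)(=O)C#CC(O/C=C/S(=O)(=O)c2ccc(C)cc2)C(C)C)cc1` replaces both esters with sulfonyl groups and gives 3200 nM, the highest number of the three.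

Compound 4 `CCCCCCC(C#CC(=O)OC)O/C=C/C(=O)OC` differs from compound 1 by propyl in place of hydrogen on a saturated chain carbon, four bonds along the chain from an oxygen on an unsaturated carbon and a triple-bonded carbon. Within the data shown here, the only measured step on that carbon is the one from compound 1 to compound 2, a branching rather than a lengthening of the chain, and it moved the number only modestly. Among the measured compounds shown here, no measured step lengthens the chain itself, so the expectation for compound 4 is a number close to compound 1, with the step estimated as a 1.3-fold higher number from compound 1 to compound 4 (0.10 log units; within the scatter) and wide uncertainty. Compound 4 is therefore expected at 400 nM, between 150 nM and 1200 nM.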

Compound 4, concentration for 50% growth inhibition: 3300 nM
The estimate for compound 4 lay 8.3-fold (0.92 log units) below the measured number; measured number above the stated range.
By their numbers in this assay, from the lowest: compound 1; then compound 2; then compounds 3 and 4 (each within the scatter of the next).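

In this assay, the length of the chain on this carbon matters more than the earlier branching step suggested: hexyl in place of propyl gives a 10-fold higher number from compound 1 to compound 4 (1.01 log units; beyond the scatter) and is a large step, whereas the move to isopropyl gave only a 2.3-fold higher number from compound 1 to compound 2 (0.37 log units; beyond the scatter) and was modest. Hexyl in place of isopropyl still shows a 4.4-fold higher number from compound 2 to compound 4 (0.64 log units; beyond the scatter) on the same carbon, so among these three esters the number does not stay near that of compound 1 once the chain is lengthened. Nothing shown accounts for this rise.

The compounds shown leave open whether the rise sets in gradually, with butyl or pentyl, or abruptly at hexyl. They also leave open how a shorter chain such as ethyl, or a hexyl chain ending in an amine or a carboxylic acid, would read here.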